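The source may report more compounds than this note shows. Statements on the series, on what has been measured and on what is new or still open speak of the compounds shown alone.

Measured so far:
compound 1, `C=CC[C@@H]1CN[C@H](C(=O)N2CCC[C@H]2C#N)C1`: 38%
compound 2, `N#C[C@@H]1CCCN1C(=O)[C@@H]1C[C@H](C(=O)N2CCCCCCC2)CN1`: 63%
compound 3, `C[C@@H]1N[C@H](C(=O)N2CCC[C@H]2C#N)C[C@@H]1C(=O)N1CCSCC1`: 92%

In an assay on the whole organism (plasma, strain Sprague-Dawley) for inhibition of Dipeptidyl peptidase 4 (Rattus norvegicus), with a stated time of 6 h, at a dose of 1 mg/kg by the oral route (on this read-out lower numbers stand for less inhibition and higher numbers for more inhibition at the one dose given (going by the name of the read-out)), compound 1 gives 38% and stands lowest of the three numbers. Compound 2 gives 63%, a number beyond the scatter above compound 1, and compound 3 gives 92%, further above still. Compound 4, `N#C[C@@H]1CCCN1C(=O)[C@@H]1C[C@H](CCO)CN1`, has not been measured. It differs from compound 1 in one place: hydroxymethyl in place of vinyl on a saturated chain carbon bound to a saturated ring carbon. Going by the values given here, no measured pair shows this kind of change, so the size of the step is open. The expectation is a small step, likely within or just beyond the scatter, and if anything upward: compound 4 is expected to give 45%, between 25% and 65%, a step of a number 7 percentage points higher from compound 1 to compound 4 (within the scatter) from compound 1.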

Compound 4, a percentage reported as inhibition, in the whole organism at one dose (the size of the read-out at that dose, not a potency): 64%
Beside the measured number, compound 4's estimate is 19 percentage points below it, within the range that was stated.
By their numbers in this assay, from the lowest: compound 1; then compounds 2 and 4 (each within the scatter of the next); then compound 3.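

In this assay, hydroxymethyl in place of vinyl on a saturated chain carbon bound to a saturated ring carbon gives a number 26 percentage points higher from compound 1 to compound 4 (beyond the scatter). The count of heavy atoms stays the same while a hydrogen-bond donor and acceptor enter, so this position responds to a change of atoms even without a change in group size. No supporting measurement accounts for the step. On these data alone, whether an amine, a carboxylic acid or a longer chain at this place would go further remains open. One step also cannot show how far the trend extends.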